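The source may hold more compounds than are shown below. What is called first, only, known or untested is meant among the compounds shown, and "the series" means these compounds.

Compound 1 `CCCc1ccc(-c2cc(=O)c3c(o2)C(CC)(CC)C(=O)C(CC)=C3O)cc1`, compound 2 `CCC1=C(O)c2c(oc(-c3ccc(COC)cc3)cc2=O)C(CC)(CC)C1=O` and compound 3 `CCC1=C(O)c2c(oc(-c3cccc(F)c3)cc2=O)C(CC)(CC)C1=O` share one core and differ only in the aryl group attached to it on an aromatic carbon next to the ring oxygen. In a functional assay on KBVIN cells (Homo sapiens) for antiproliferative activity, read by sulforhodamine B assay, with a stated time of 3 days (a higher number here means that more compound is needed for the effect, a lower number that less compound is needed), compound 1 gives 12.2 uM, the highest of the three numbers. Compound 2 gives 3.4 uM, and compound 3 gives 3.09 uM. The two changes away from compound 1 both lowered the number beyond the scatter, with a 3.6-fold lower number from compound 1 to compound 2 (0.55 log units; beyond the scatter) and a 3.9-fold lower number from compound 1 to compound 3 (0.60 log units; beyond the scatter), whereas a 1.1-fold lower number from compound 2 to compound 3 (0.04 log units; within the scatter) lies within it.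

Compound 4 `CCC1=C(O)c2c(oc(-c3ccc(OC)cc3C)cc2=O)C(CC)(CC)C1=O` has not yet been measured. It differs from compound 1 by 4-methoxy-2-methylphenyl in place of 4-propylphenyl on an aromatic carbon. Both measured replacements of the aryl group of compound 1 lowered the number by a modest amount, and the entering group brings in a methoxy, as the step to compound 2 did, so a modest downward step is expected for compound 4, a 2.4-fold lower number from compound 1 to compound 4 (0.39 log units; beyond the scatter). Going by the values given here, no measured compound carries a methyl on the aryl group, so the range must be kept wide. Compound 4 is estimated at 5 uM, with a range from 2 uM to 12 uM.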

Compound 4, concentration for half-maximal effect: 2.62 uM
Beside the measured number, compound 4's estimate is 1.9-fold (0.28 log units) above it; measured number inside the range.
By their numbers in this assay, from the lowest: compounds 4, 3 and 2 (each within the scatter of the next); then compound 1.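

In this assay the exchange of 4-propylphenyl for 4-methoxy-2-methylphenyl gives a 4.7-fold lower number from compound 1 to compound 4 (0.67 log units; beyond the scatter) at this position, so a third and differently substituted aryl group also separates from compound 1 beyond the scatter. The new group cannot be told apart from the two earlier replacements, with a 1.2-fold lower number from compound 3 to compound 4 (0.07 log units; within the scatter) and a 1.3-fold lower number from compound 2 to compound 4 (0.11 log units; within the scatter) both within the scatter. Compounds 2, 3 and 4 therefore stand at one level despite carrying three different aryl groups, and among these four compounds only compound 1, with its 4-propylphenyl, stands apart. Nothing measured here bears on why the 4-propylphenyl compound differs from the other three.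

The compounds shown leave open what the methoxy and the methyl of compound 4 each contribute, as no compound here carries one without the other on the aryl ring. They also leave open how this position would respond to an aryl group bearing an amine or a carboxylic acid, or to a chain longer than the propyl of compound 1.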